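Series notes: aryl replacement at the pyridine-adjacent position

This account rests on a few compounds, and the source may have more. Where it says the series, first, only, none or still open, it means among the compounds named here.

Compound 3 `CC(C(=O)NCc1ccc(C(F)(F)F)nc1-c1ccc2cc[nH]c2c1)c1ccc(NS(C)(=O)=O)c(F)c1` gives 20.3 nM in an assay on CHO cells for antagonist activity at transient receptor potential cation channel subfamily V member 1 (Homo sapiens), read by FLIPR (on this read-out higher numbers stand for weaker inhibition and lower numbers for stronger inhibition), the highest of the three numbers recorded. Compound 1 `CC(C(=O)NCc1ccc(C(F)(F)F)nc1-c1cccc(Cl)c1)c1ccc(NS(C)(=O)=O)c(F)c1` gives 0.5 nM and compound 2 `CC(C(=O)NCc1ccc(C(F)(F)F)nc1-c1ccc(Cl)c(Cl)c1)c1ccc(NS(C)(=O)=O)c(F)c1` gives 0.9 nM; the step of a 1.8-fold higher number from compound 1 to compound 2 (0.26 log units; within the scatter) is small, whereas a 41-fold higher number from compound 1 to compound 3 (1.61 log units; beyond the scatter) and a 23-fold higher number from compound 2 to compound 3 (1.35 log units; beyond the scatter) are both large and show that the group at this position governs the read-out strongly.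

Compound 4 `CC(C(=O)NCc1ccc(C(F)(F)F)nc1CCc1ccccc1)c1ccc(NS(C)(=O)=O)c(F)c1` is the next member. The change from compound 3 is phenethyl in place of 1H-indol-6-yl on an aromatic carbon. Among the measured compounds shown here, no measured step involves phenethyl, and both large steps recorded run from a chlorinated phenyl to the indolyl group, so they do not indicate the direction of this new change. Given that uncertainty, a step in this assay of moderate size in either direction is conceivable, and the estimate for compound 4 is placed near compound 3 with a wide range. For compound 4 the expected value is 25 nM (range 4 nM to 150 nM), an expected step of a 1.2-fold higher number from compound 3 to compound 4 (0.09 log units; within the scatter).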

Compound 4, inhibition constant: 1.4 nM
For compound 4 the middle estimate is 18-fold (1.25 log units) above the measured one, and the stated range ends above it.
By their numbers in this assay, from the lowest: compounds 1, 2 and 4 (each within the scatter of the next, the first and the last beyond it); then compound 3.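

In this assay, a 15-fold lower number from compound 3 to compound 4 (1.16 log units; beyond the scatter) shows that this position does not need a chlorinated phenyl attached directly to the core, as phenethyl also gives a low number. Its placement among the chlorinated compounds is mixed: a 1.6-fold higher number from compound 2 to compound 4 (0.19 log units; within the scatter), while a 2.8-fold higher number from compound 1 to compound 4 (0.45 log units; beyond the scatter), so compound 4 matches the 3,4-dichlorophenyl compound but not the 3-chlorophenyl compound. No measurement here bears on the reason for these steps.

Compound 3 differs from the other three in both its ring system and its hydrogen-bond donor, so the compounds shown do not separate these two features. Also open, going by these compounds, is how a longer chain ending in phenyl, or a chain ending in an amine, would read at this position.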